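The compounds below may be only part of what the source reports. "The series", "measured", "known", "first", "only" and "open" are said of these compounds alone.

Compound 1, `CCCCSC(=S)C1=C(Nc2ccc(Cl)cc2Cl)CC(C)(C)CC1=O`, is the starting point. In a functional assay on PBMC cells (Homo sapiens) for inhibition, read by thymidine incorporation, with a stated time of 72 h (a higher number here means a weaker inhibitor, a lower number a stronger inhibitor), compound 1 gives > 50 ug/mL, which is a limit of the assay rather than a measured number. Among the compounds with values here, the one measured neighbour, compound 2, `CC1(C)CC(=O)C(C(=S)SCCO)=C(Nc2ccc(Cl)cc2Cl)C1`, differs from compound 1 by a hydroxy in place of ethyl on a saturated chain carbon, two bonds along the chain from a sulfur. In this assay compound 2 gives > 50 ug/mL, also a limit. Within the data shown here, the step that the two limits leave unreadable from compound 1 to compound 2 is therefore not readable, and the limit of > 50 ug/mL in this assay, at which 2 of the 2 values shown sit, is all the data offer: both values shown sit at that limit, so no measured step is available to size the change ahead.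

Compound 3, `CCCCSC(=S)C1=C(Nc2ccc(Cl)cc2)CC(C)(C)CC1=O`, differs from compound 1 by hydrogen in place of chloro on an aromatic carbon. With no readable step to lean on, compound 3 is expected to give 50 ug/mL, with a range from 15 ug/mL to 150 ug/mL. The expected step of a number no higher from compound 1 to compound 3 (the limit leaves the size open) carries no direction beyond the scatter.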

Compound 3, half-maximal inhibitory concentration: > 50 ug/mL
Compound 3: only a limit was reported; the forecaster's own chance of this, stated with the estimate: 70%; the middle value sits exactly at the limit.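

Compound 3, like compound 1, returned only a limit of the assay, so the step between them cannot be read: the limit of > 50 ug/mL in this assay, at which 3 of the 3 values shown sit. The compounds shown leave open how strongly any of them inhibits in this assay, and whether swapping 2,4-dichlorophenyl for 4-chlorophenyl changes that.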